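A few compounds are considered here, and "the series" means these few. Any claim that something is new, unique, unknown or untested is made for them only; others in the source may bear on it.

Compound 1 `CCNC(=O)c1noc(-c2cc(C(C)C)c(O)cc2O)c1-c1cc(CO)no1`: 5 nM
Compound 2 `CCNC(=O)c1noc(-c2cc(C(C)C)c(O)cc2O)c1-c1cc(COCC(=O)OC)no1`: "not determined" (no result reported)
Compound 3 `CCNC(=O)c1noc(-c2cc(C(C)C)c(O)cc2O)c1-c1cc(CN)no1`: "not determined" (no result reported)

In a functional assay on A2780 cells (Homo sapiens) for inhibition (a higher number here means a weaker inhibitor, a lower number a stronger inhibitor), compound 1 gives 5 nM. Compound 2 and compound 3 share the same core as compound 1 but carry different groups on the outer ring; in this assay compound 2 gives "not determined" (no result reported) and compound 3 gives "not determined" (no result reported), so compound 3 stands without a number against which the next change can be measured. Compound 4 `CCNCc1cc(-c2c(C(=O)NCC)noc2-c2cc(C(C)C)c(O)cc2O)on1` differs from compound 3 by ethyl in place of hydrogen on an amine nitrogen. Going by the values given here, with no measured step available, a change of this kind is expected to move inhibition by no more than the usual scatter, in either direction, keeping compound 4 near the potency seen for compound 1. Compound 4 is estimated to give 15 nM in this assay, within a range from 3 nM to 80 nM.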

Compound 4, half-maximal inhibitory concentration: 45 nM
Estimate against measurement, compound 4: 3.0-fold (0.48 log units) below; low and high end bracket the measured number.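

In this assay, the position can now be compared across two different groups: ethylamino in place of hydroxy on the saturated chain carbon gives a 9.0-fold higher number from compound 1 to compound 4 (0.95 log units; beyond the scatter), so compound 4 is the weaker inhibitor. On these data alone, the step from compound 3 to compound 4 cannot be read, as compound 3 has no number, so the share of the ethyl alone stays unknown. No available evidence explains this loss of inhibition. Still open, as far as these compounds go, is how a methylamino group, a longer chain on the amine nitrogen or a carboxylic acid would compare at this position.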